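The compounds below may be only part of what the source reports. "The series", "measured", "known", "first", "only" and "open" are said of these compounds alone.

Compound 1 `O=C(OC1CCC(CN2CCN(c3cc(=O)c4cc(C(F)(F)F)cc([N+](=O)[O-])c4s3)CC2)CC1)C1CCCCC1` gives in an ADME assay on Vero cells (Chlorocebus sabaeus) for cytotoxicity, read by MTT assay, with a stated time of 48 h (a higher number here means a weaker inhibitor, a lower number a stronger inhibitor), a limit of > 64 ug/mL.
Compound 2 `O=C(OC1CCC(CN2CCN(c3cc(=O)c4cc(C(F)(F)F)cc([N+](=O)[O-])c4s3)CC2)CC1)c1ccc(F)cc1` gives in this assay a limit of > 64 ug/mL.
Compound 3 `O=C(OC1CCC(CN2CCN(c3cc(=O)c4cc(C(F)(F)F)cc([N+](=O)[O-])c4s3)CC2)CC1)c1cccs1` gives in this assay a limit of > 64 ug/mL.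

Compound 3 therefore stands at a limit rather than a number, and the same holds for every value shown here: all three sit at the limit of > 64 ug/mL in this assay, at which 3 of the 3 values shown sit. Compound 4 `Cc1ccc(C(=O)OC2CCC(CN3CCN(c4cc(=O)c5cc(C(F)(F)F)cc([N+](=O)[O-])c5s4)CC3)CC2)cc1` differs from compound 3 in one place: 4-methylphenyl in place of thiophen-2-yl on a carbonyl carbon. Among the measured compounds shown here, the steps that bear on this change are a step that the two limits leave unreadable from compound 1 to compound 3 and a step that the two limits leave unreadable from compound 2 to compound 3, and likewise a step that the two limits leave unreadable from compound 1 to compound 2; none of them can be read, since both ends of each sit at the limit. No step beyond the scatter is therefore expected in this assay for compound 4, whose value is estimated at 100 ug/mL, in the range 40 ug/mL to 300 ug/mL, a change of a step that the limit leaves unreadable from compound 3 to compound 4 that is most likely to appear again only as a limit.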

Compound 4, half-maximal inhibitory concentration: > 64 ug/mL
Compound 4 gave a limit, no number; the forecaster's own chance of this, stated with the estimate: 85%; the middle value does not contradict the limit.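

Compound 4 gives only a limit, as do compound 1, compound 2 and compound 3, so none of the steps from those three to compound 4 can be read: the limit of > 64 ug/mL in this assay, at which 4 of the 4 values shown sit.

Going by these compounds, what stays open is how these four compounds truly compare in this assay, since none of them has an actual number.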